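A few compounds are considered here, and "the series" means these few. Any claim that something is new, unique, unknown or untested is made for them only; others in the source may bear on it.

Measured so far in a functional assay on HCT-116 cells (Homo sapiens) for cytotoxicity, read by sulforhodamine B assay, with a stated time of 48 h, tested at 0.1 uM; a higher number here means a weaker effect of the compound at the concentration tested, a lower number a stronger effect:
compound 1 `COc1cc(-c2cc(/C=C/C(=O)c3ccc(Cl)c(Cl)c3)[nH]n2)cc(OC)c1OC` gives 100%
compound 2 `COc1ccc(C(=O)/C=C/c2cc(-c3cc(OC)c(OC)c(OC)c3)n[nH]2)cc1OC` gives 100%
compound 3 `COc1ccc(C(=O)/C=C/c2cc(-c3cc(OC)c(OC)c(OC)c3)n[nH]2)cc1` gives 102%

All three share one core and differ only in the aryl group on the carbonyl carbon or in a single methoxy on it. Compound 3 sits within the scatter of both other compounds: the step of a number 2 percentage points higher from compound 1 to compound 3 (within the scatter) and the step of a number 2 percentage points higher from compound 2 to compound 3 (within the scatter) are both within the scatter, as is no change at the digits printed from compound 1 to compound 2 (within the scatter). At the concentration used in this assay, none of the three shows a measurable effect.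

Compound 4 `COc1cc(-c2cc(/C=C/C(=O)c3ccc(F)c(F)c3)[nH]n2)cc(OC)c1OC` is not yet measured. Its change from compound 3: 3,4-difluorophenyl in place of 4-methoxyphenyl on a carbonyl carbon. For the measured compounds named here, the steps that bear on this are the two earlier exchanges of the aryl group on the carbonyl carbon, no change at the digits printed from compound 1 to compound 2 (within the scatter) and a number 2 percentage points higher from compound 1 to compound 3 (within the scatter), together with a number 2 percentage points higher from compound 2 to compound 3 (within the scatter); all of them were within the scatter, so no step beyond the scatter is expected in this assay in either direction. Compound 4 is therefore estimated at 100%, with a range from 90% to 110%. The implied step a number 2 percentage points lower from compound 3 to compound 4 (within the scatter) is expected to stay within the scatter.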

Compound 4, a percentage reported as activity, at one concentration (the size of the read-out at that concentration, not a potency): 102%
Estimate against measurement, compound 4: 2 percentage points below; the range from low to high includes it.
By their numbers in this assay, from the lowest: compounds 1, 2, 3 and 4 (each within the scatter of the next).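

In this assay, 3,4-difluorophenyl on the carbonyl carbon gives no change at the digits printed from compound 3 to compound 4 (within the scatter), then a number 2 percentage points higher from compound 2 to compound 4 (within the scatter), and finally a number 2 percentage points higher from compound 1 to compound 4 (within the scatter), so all four aryl groups at this position remain indistinguishable. The exchange from 4-methoxyphenyl to 3,4-difluorophenyl also takes the hydrogen-bond acceptor count of this group from 1 to 0, and the read-out does not separate the two compounds. No further data are available to explain this flat read-out.

From the compounds shown here alone, an amine or a carboxylic acid on the aryl group at the carbonyl carbon remains open, as does whether either would give a read-out beyond the scatter of these four compounds. A single-concentration read-out with no visible effect also leaves open how these compounds would separate at other concentrations.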